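The source may report more compounds than this note shows. Statements on the series, on what has been measured and on what is new or still open speak of the compounds shown alone.

Measured so far:
- Compound 1, `COc1ccc(N(C)c2ncnc3c2ncn3Cc2ccc(OC)c(OC)c2)cc1`: in a functional assay on AGS cells (Homo sapiens) for antiproliferative activity, read by MTT assay, with a stated time of 48 h (on this read-out lower numbers stand for stronger inhibition of growth and higher numbers for weaker inhibition of growth), compound 1 gives > 100000 nM, which is a limit of the assay rather than a number.
- Compound 2, `COc1ccc(N(C)c2ncnc3c2ncn3Cc2cc(OC)cc(OC)c2)cc1`: compound 2 gives > 100000 nM, again only a limit.
- Compound 3, `COc1ccc(N(C)c2nc(Cl)nc3c2ncn3Cc2ccc(OC)c(OC)c2)cc1`: compound 3 gives 56000 nM.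

Compound 3 carries chloro in place of hydrogen on an aromatic carbon relative to compound 1, and this is also how the cores of the two pairs differ; the step is an at least 1.7-fold lower number from compound 1 to compound 3 (0.25 log units; that floor lies within the scatter). Compound 2 carries 3,5-dimethoxyphenyl in place of 3,4-dimethoxyphenyl on a saturated chain carbon bound to an aromatic nitrogen relative to compound 1, but the step that the two limits leave unreadable from compound 1 to compound 2 stays hidden because of the limit of > 100000 nM in this assay, at which 2 of the 3 values shown sit.

Compound 4, `COc1ccc(N(C)c2nc(Cl)nc3c2ncn3Cc2cc(OC)cc(OC)c2)cc1`, is not yet measured. It carries 3,5-dimethoxyphenyl in place of 3,4-dimethoxyphenyl on a saturated chain carbon bound to an aromatic nitrogen relative to compound 3, the same change as between compound 1 and compound 2. Since that earlier step could not be read, compound 4 is expected to sit close to compound 3 or weaker, a step of a 1.4-fold higher number from compound 3 to compound 4 (0.15 log units; within the scatter). The estimate for compound 4 is 80000 nM, between 30000 nM and 250000 nM.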

Compound 4, concentration for 50% growth inhibition: 69000 nM
For compound 4 the middle estimate is 1.2-fold (0.06 log units) above the measured one; measured number inside the range.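

On the core of compound 3, 3,5-dimethoxyphenyl in place of 3,4-dimethoxyphenyl in this assay gives a 1.2-fold higher number from compound 3 to compound 4 (0.09 log units; within the scatter), so the swap makes no readable difference there. Chloro in place of hydrogen on an aromatic carbon can be followed with both dimethoxyphenyl groups, where the new step is an at least 1.4-fold lower number from compound 2 to compound 4 (0.16 log units; that floor lies within the scatter), and the two steps compare as follows: the same change on two cores in this assay, an at least 1.7-fold lower number (0.25 log units; that floor lies within the scatter) from compound 1 to compound 3 and an at least 1.4-fold lower number (0.16 log units; that floor lies within the scatter) from compound 2 to compound 4; the limit leaves it open whether they differ. This does not show that either change carries over from one core to another by the same amount, and the dimethoxyphenyl swap cannot be read on the core without chloro: the limit of > 100000 nM in this assay, at which 2 of the 4 values shown sit.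

The compounds shown leave open what an amine or a longer chain in place of chloro would give. They also leave open whether a single methoxy group on the phenyl ring would change the number.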